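The compounds below may be only part of what the source reports. "The series", "measured", "known", "first", "only" and "open" are said of these compounds alone.

Going by the values given here, compound 2 `O=C(c1ccccc1)N1CCC(NCCSC(c2ccc(F)cc2)c2ccc(F)cc2)CC1` stands at the bottom of the two numbers known in an ADME assay on microsomes from liver (Rattus norvegicus) for metabolic stability, read by LC-MS, using NADPH, with a stated time of 60 min, tested at 10 uM; a higher number here means that more of the compound is left, a lower number that less of the compound is left: compound 2 gives 7%, whereas compound 1 `OC(Cc1ccccc1)CN1CCC(NCCSC(c2ccc(F)cc2)c2ccc(F)cc2)CC1` gives 74%. Among the compounds with values here, the one measured step connecting them, a number 67 percentage points lower from compound 1 to compound 2 (beyond the scatter), concerns a benzoyl taking the place of a 2-hydroxy-3-phenylpropyl on the ring nitrogen and has nothing in common with the change now under consideration. Compound 3 `O=C(c1ccc(F)cc1F)N1CCC(NCCSC(c2ccc(F)cc2)c2ccc(F)cc2)CC1` differs from compound 2 by 2,4-difluorophenyl in place of phenyl on a carbonyl carbon. Within the data shown here, no measured step bears on this change, so nothing in the data argues for a shift beyond the scatter in either direction; the step from compound 2 to compound 3 is therefore expected to be small, a number 5 percentage points higher from compound 2 to compound 3 (within the scatter). On that basis compound 3 is estimated to give 12% in this assay, with a range from 3% to 30%.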

Compound 3, percent of the compound remaining: 85%
The estimate for compound 3 lay 73 percentage points below the measured number; measured number outside the range, above it.
By their numbers in this assay, from the lowest: compound 2; then compound 1; then compound 3.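

In this assay, the group on a carbonyl carbon whose other neighbour is an amide-type nitrogen in a ring proves decisive: 2,4-difluorophenyl in place of phenyl gives a number 78 percentage points higher from compound 2 to compound 3 (beyond the scatter) as a large step. The earlier fall on going to benzoyl therefore does not hold for every aroyl group on this ring nitrogen, since (2,4-difluorophenyl)carbonyl in place of 2-hydroxy-3-phenylpropyl gives a number 11 percentage points higher from compound 1 to compound 3 (beyond the scatter) as a modest step. Nothing available explains why this change has so large an effect.

The compounds shown leave open whether both fluorines are needed, or whether 2-fluorophenyl or 4-fluorophenyl alone would give a similar number. They also leave open whether 2,4-dichlorophenyl or a pyridyl group on the same carbonyl carbon would behave in the same way.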